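The source may report more compounds than this note shows. Statements on the series, on what has been measured and on what is new or still open speak of the compounds shown alone.

The study follows the fate of a small set of compounds in an ADME assay on S9 fraction from liver (Rattus norvegicus) for metabolic stability, read by LC-MS, using NADPH, with a stated time of 30 min; a higher number here means that more of the compound is left, a lower number that less of the compound is left. Compound 1, with the structure `CCCCCCCCc1ccc(OCC(=O)Cn2nnc(-c3cccc(S(=O)(=O)N(C)C)c3)n2)cc1`, gives 9% in this assay. Compound 2, with the structure `CCCCCCCCc1ccc(OCC(=O)Cn2nnc(-c3ccncc3)n2)cc1`, returns only a limit of the assay, < 5%, and the reading the limit of < 5% in this assay, at which 1 of the 3 values shown sits, marks where that limit sits. The change between the two is pyridin-4-yl in place of 3-(dimethylsulfamoyl)phenyl on an aromatic carbon, and the step it made is a number at least 4 percentage points lower from compound 1 to compound 2 (that floor lies within the scatter). Compound 3, with the structure `CCCCCCCCc1ccc(OCC(=O)Cn2nnnc2-c2cccc(S(=O)(=O)N(C)C)c2)cc1`, has the same atoms as compound 1 joined differently; how the two cores differ is not broken down here. In this assay compound 3 gives 24%, while compound 1 gives 9%, so compound 3 has the higher of the two numbers, and the gap to compound 1 lies beyond the usual scatter.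

Compound 4, with the structure `CCCCCCCCc1ccc(OCC(=O)Cn2nnnc2-c2ccncc2)cc1`, has not yet been measured. It differs from compound 3 by pyridin-4-yl in place of 3-(dimethylsulfamoyl)phenyl on an aromatic carbon. This is the same kind of change as that from compound 1 to compound 2, though the surroundings of the place are not the same: in compound 3 the carbon is described as next to the ring atom that bears a large group, whereas in compound 1 it is two ring bonds from the ring atom that bears a large group. Given the step seen from compound 1 to compound 2, the expected step is a number 14 percentage points lower from compound 3 to compound 4 (beyond the scatter), a fall resting on a number at least 4 percentage points lower from compound 1 to compound 2 (that floor lies within the scatter) and on the higher starting point of compound 3 at 24%. Compound 4 is therefore estimated to give 10% in this assay, within a range from 3% to 18%.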

Compound 4, percent of the compound remaining: 24%
Beside the measured number, compound 4's estimate is 14 percentage points below it, and the stated range ends below it.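

On the core of compound 3, putting pyridin-4-yl in place of 3-(dimethylsulfamoyl)phenyl leaves the reading in this assay where it was, with no change at the digits printed from compound 3 to compound 4 (within the scatter); on this core, then, the smaller group gives up nothing that this assay can detect. Whether the change carries over from one core to the other in the same way cannot be decided from the two cases, and neither a shared effect nor a core-dependent one is shown: the same change on two cores in this assay, a number at least 4 percentage points lower (that floor lies within the scatter) from compound 1 to compound 2 and no change at the digits printed (within the scatter) from compound 3 to compound 4; the limit leaves it open whether they differ. The reading of compound 2 is a limit and not a number, which leaves the size of the step on the core of compound 1 unknown: the limit of < 5% in this assay, at which 1 of the 4 values shown sits.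

The compounds shown cover only these two groups at this place, on two cores, so they do not tell how a plain phenyl ring, a morpholine or a carboxylic acid on the aromatic ring would read in this assay. Also open, going by these compounds, is whether the picture would hold with a shorter chain in place of the long alkyl chain, or with an alcohol in place of the carbonyl shared by all of them.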